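A few compounds are considered here, and "the series" means these few. Any claim that something is new, unique, unknown or untested is made for them only; others in the source may bear on it.

Compounds measured in an assay on Sf9 cells for inhibition of protein deacetylase HDAC6 (Homo sapiens), read by fluorescence, with a stated time of 40 min, tested at 100 nM; on this read-out lower numbers stand for less inhibition and higher numbers for more inhibition at the one concentration tested (going by the name of the read-out):
compound 1 `O=C(NO)c1ccc(NCc2nc(-c3ccccc3)nn2-c2cccc(Cl)c2)cc1`: 62.3%
compound 2 `O=C(NO)c1ccc(NCc2nc(-c3ccc(F)cc3)nn2-c2ccccc2)cc1`: 70.9%
compound 3 `O=C(NO)c1ccc(NCc2nc(-c3cc4ccccc4s3)nn2-c2ccccc2)cc1`: 65.5%

Compound 1 gives the lowest of the three numbers in this assay, at 62.3%. Its nearest neighbour is compound 3, which gives 65.5%, a gap within the usual scatter. The furthest is compound 2, which gives 70.9%, again within the scatter, so the three compounds cannot be ordered against one another on these numbers.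

Compound 4 `Cc1cc(C)cc(-n2nc(-c3ccccc3)nc2CNc2ccc(C(=O)NO)cc2)c1` is the next compound to be measured. It differs from compound 1 in one place: 3,5-dimethylphenyl in place of 3-chlorophenyl on an aromatic nitrogen. Among the compounds with values here, the only step between measured compounds that differ in one place is a number 5.4 percentage points lower from compound 2 to compound 3 (within the scatter), a change on an aromatic carbon rather than on the aromatic nitrogen where compound 4 differs, and that step stayed within the scatter. Within the data shown here, no measured step addresses a change at the aromatic nitrogen, so the single step available offers only indirect guidance. On that basis no step beyond the scatter is expected in this assay from compound 1 to compound 4, and the estimated change is a number 1.7 percentage points higher from compound 1 to compound 4 (within the scatter). Compound 4 is therefore expected to give about 64% in this assay, in the range of 50% to 78%.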

Compound 4, a percentage reported as inhibition, at one concentration (the size of the read-out at that concentration, not a potency): 49.8%
The estimate for compound 4 lay 14.2 percentage points above the measured number; measured number below the stated range.
By their numbers in this assay, from the lowest: compound 4; then compounds 1, 3 and 2 (each within the scatter of the next).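

In this assay, the aromatic nitrogen of the five-membered ring proves to be a place where the choice of group can move the number: 3,5-dimethylphenyl in place of 3-chlorophenyl gives a number 12.5 percentage points lower from compound 1 to compound 4 (beyond the scatter), the only step among these compounds that lies beyond the scatter. The two groups are close in what can be counted, since each has one six-membered aromatic ring of carbon only, no hydrogen-bond donors or acceptors and no net charge, with 7 heavy atoms leaving and 8 entering, so those counts do not separate them. Nothing available accounts for the step, which stands here as an observation without an explanation.

The change removes a chlorine and adds two methyl groups at once, so the compounds shown leave open whether the lower number goes with the loss of the chlorine, with one methyl group or with the pair of them. They also leave open how this position would respond to a ring carrying a methoxy group, an amine or a carboxylic acid.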